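Cytotoxicity notes on a chloroaryl amide sulfonamide series

The compounds below may be only part of what the source reports. "The series", "measured", "known", "first", "only" and "open" are said of these compounds alone.

Two members of the series have been measured in a functional assay on C8166 cells (Homo sapiens) for cytotoxicity, read by MTT assay; a higher number here means that more compound is tolerated, a lower number that less compound is tolerated. Compound 1 `Cc1cccc(C(=O)Nc2cc(Cl)ccc2OCC(=O)Nc2ccc(S(N)(=O)=O)cc2C)c1` gives 52900 nM in this assay. Compound 2 `COc1ccc(C(=O)Nc2cc(Cl)ccc2OCC(=O)Nc2ccc(S(N)(=O)=O)cc2C)cc1` gives 69500 nM. For the measured compounds named here, the sole measured step, a 1.3-fold higher number from compound 1 to compound 2 (0.12 log units; within the scatter), is within the scatter, so compound 2 stands beside compound 1 with no separation that can be read as real; it is simply the compound with the nearest measured neighbour at that distance.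

Compound 3 `Cc1cc(S(N)(=O)=O)ccc1NC(=O)COc1ccc(Cl)cc1NC(=O)/C=C/c1ccccc1` is not yet measured. It differs from compound 2 by 2-phenylethenyl in place of 4-methoxyphenyl on a carbonyl carbon. Going by the values given here, the only step that bears on it is a 1.3-fold higher number from compound 1 to compound 2 (0.12 log units; within the scatter), a change on the same carbonyl carbon that produced nothing beyond the scatter. There is no other measured comparison to draw on, and nothing in the two numbers shown suggests that a further exchange at this position should move this assay noticeably. From this the expected step is a 1.1-fold lower number from compound 2 to compound 3 (0.05 log units; within the scatter), meaning no change beyond the scatter. For compound 3 the estimate in this assay is 62000 nM, with a range from 25000 nM to 150000 nM.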

Compound 3, half-maximal cytotoxic concentration: 163000 nM
For compound 3 the middle estimate is 2.6-fold (0.42 log units) below the measured one, and the stated range ends below it.
By their numbers in this assay, from the lowest: compounds 1 and 2 (each within the scatter of the next); then compound 3.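

Working notes on the carbonyl carbon position: in this assay, this position can move the number beyond the scatter, with a 2.3-fold higher number from compound 2 to compound 3 (0.37 log units; beyond the scatter) and a 3.1-fold higher number from compound 1 to compound 3 (0.49 log units; beyond the scatter), both modest. For the compounds shown here, the earlier exchange of 3-methylphenyl for 4-methoxyphenyl stayed within the scatter, whereas 2-phenylethenyl, the only one of the three groups with a double bond outside aromatic rings, stands apart from both, with more compound tolerated. Nothing available explains this separation, so the result stands as an observation only.

The compounds shown leave open whether the double bond itself goes with the higher number or whether the two-carbon chain carrying the ring is enough, a question that 2-phenylethyl, the saturated counterpart of 2-phenylethenyl, would address. Also open, as far as these compounds go, is whether the aromatic ring is needed at this carbonyl carbon at all, as a plain alkyl chain, an amine or a carboxylic acid in its place could show, and whether the step to 2-phenylethenyl would hold with a change elsewhere in the shared core.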